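The source may hold more compounds than are shown below. What is called first, only, known or untested is meant among the compounds shown, and "the series" means these compounds.

Measured compounds in a functional assay on the whole organism (strain albino) with Rattus norvegicus as the target, read by paw edema, with stated times of 1 h and 4 h, at a dose of 25 mg/kg by the oral route; a higher number here means a stronger effect of the compound at the dose given, a lower number a weaker effect: compound 1 `COc1ccc(Cl)cc1C(=O)Nc1ccc(C2=NN(C)C(c3ccccc3[N+](=O)[O-])C2)cc1` gives 96.5%; compound 2 `COc1ccc(Cl)cc1C(=O)Nc1ccc(C2=NNC(c3ccccc3[N+](=O)[O-])C2)cc1` gives 88.3%; compound 3 `COc1ccc(Cl)cc1C(=O)Nc1ccc(C2=NNC(c3ccc([N+](=O)[O-])cc3)C2)cc1` gives 91.3%.

Compound 2 holds the lowest of the three numbers, yet a number 8.2 percentage points lower from compound 1 to compound 2 (within the scatter) and a number 3 percentage points higher from compound 2 to compound 3 (within the scatter) both lie within the scatter, so no order among the three can be claimed. Compound 4 `COc1ccc(Cl)cc1C(=O)Nc1ccc(C2=NN(C(C)=O)C(c3ccccc3[N+](=O)[O-])C2)cc1` differs from compound 2 by acetyl in place of hydrogen on an amine nitrogen in a ring. Going by the values given here, the only measured step at this place is a number 8.2 percentage points lower from compound 1 to compound 2 (within the scatter), which stayed within the scatter; no measured step covers an acetyl there, so the expectation rests on that single small step. Compound 4 is therefore expected to give 89%, with a range from 76% to 98%. The estimated step of a number 0.7 percentage points higher from compound 2 to compound 4 (within the scatter) is expected to remain within the scatter.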

Compound 4, a percentage reported as activity, at one dose (the size of the read-out at that dose, not a potency): 92.2%
Compound 4: middle estimate off by 3.2 percentage points, on the low side; low and high end bracket the measured number.
By their numbers in this assay, from the lowest: compounds 2, 3, 4 and 1 (each within the scatter of the next).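

Acetyl on the amine nitrogen in the ring can now be set against both hydrogen and methyl in this assay, and both new steps stay within the scatter: a number 3.9 percentage points higher from compound 2 to compound 4 (within the scatter) and a number 4.3 percentage points lower from compound 1 to compound 4 (within the scatter). Hydrogen, methyl and acetyl at this position therefore cannot be told apart at this dose. No measurement offered here explains this result.

Going by these compounds, whether a longer chain such as propionyl or a benzoyl group on this nitrogen would keep the read-out in this range remains open. So does whether acetyl would behave alike with 4-nitrophenyl in place of 2-nitrophenyl.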